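The source may hold more compounds than are shown below. What is called first, only, known or untested is meant among the compounds shown, and "the series" means these compounds.

Measured in a functional assay on MHCC97H cells (Homo sapiens) for antiproliferative activity, read by MTT assay, with a stated time of 48 h; a higher number here means a weaker inhibitor, a lower number a stronger inhibitor:
- Compound 1 `COc1ccc2c(/C=C(\C)C(=O)c3cc(OC)c(OC)c([Se]C)c3)cn(C)c2c1`: 15 nM
- Compound 2 `COc1cc(C(=O)/C=C/c2c[nH]c3ccccc23)cc([N+](=O)[O-])c1OC`: 830 nM
- Compound 3 `COc1ccc2c(/C=C(\C)C(=O)c3cc(OC)c(OC)c([Se]C)c3)c[nH]c2c1`: 6 nM

Compound 3, at 6 nM, has the lowest number of the three in this assay. Compound 4 `COc1cc(C(=O)/C(C)=C/c2c[nH]c3ccccc23)cc([Se]C)c1OC` has not yet been measured. It departs from compound 3 by one change, hydrogen in place of methoxy on an aromatic carbon.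

Going by the values given here, no measured step covers this change. Among the compounds with values here, the only single-place step, a 2.5-fold lower number from compound 1 to compound 3 (0.40 log units; beyond the scatter), is hydrogen in place of methyl on an aromatic nitrogen, so it offers a guide to size and none to direction. Compound 2 also has no methoxy on that ring and gives 830 nM, but it differs from compound 3 in other places too, so that gap cannot be assigned to the methoxy. A modest rise in the number is therefore expected, with the estimated step being a 3.3-fold higher number from compound 3 to compound 4 (0.52 log units; beyond the scatter). For compound 4 the estimated value is 20 nM, with an expected range of 5 nM to 80 nM.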

Compound 4, half-maximal inhibitory concentration: 18 nM
Estimate against measurement, compound 4: 1.1-fold (0.05 log units) above, and the stated range covers the measured number.
By their numbers in this assay, from the lowest: compound 3; then compounds 1 and 4 (each within the scatter of the next); then compound 2.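

Going by these compounds alone, replacing the methoxy with hydrogen on this aromatic carbon in this assay gives a 3.0-fold higher number from compound 3 to compound 4 (0.48 log units; beyond the scatter) and so provides the only measured single-place step on this ring, where the earlier step concerned the aromatic nitrogen. The methoxy is not required for a nanomolar number, as compound 4 still gives 18 nM in that assay, but the step lies beyond the scatter, so the presence of the group at this position does register in the read-out. No data at hand bear on why the number moves.

The compounds shown leave open whether a hydroxyl, an ethoxy or a fluorine on this aromatic carbon would give a number closer to that of compound 3 or of compound 4. Also open, on these data alone, is whether the step would be the same size with a methyl on the aromatic nitrogen, as in compound 1.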